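Cytotoxicity notes: one more chain on compound 3

A few compounds are considered here, and "the series" means these few. Any claim that something is new, unique, unknown or untested is made for them only; others in the source may bear on it.

Measured in a functional assay on HT-29 cells (Homo sapiens) for cytotoxicity, read by XTT assay, with a stated time of 72 h; a lower number here means a stronger inhibitor, a higher number a weaker inhibitor:
Compound 1 `CC(C)=CCC/C=C(\C)Cc1c(O)cc(O)c2c(=O)cc(-c3ccccc3)oc12`: 32000 nM
Compound 2 `C=C1CC[C@H]2C(C)(C)CCC[C@]2(C)[C@H]1CC/C(C)=C/Cc1c(O)cc2oc(-c3ccc(O)cc3)c(O)c(=O)c2c1O`: > 100000 nM (a limit)
Compound 3 `CC(C)=CCC/C=C(\C)Cc1c(OC/C=C(\C)CCC=C(C)C)cc(O)c2c(=O)cc(-c3ccccc3)oc12`: > 100000 nM (a limit)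

Compound 3 carries only a limit and no number, and the ceiling in question is the limit of > 100000 nM in this assay, at which 2 of the 3 values shown sit. Compound 4 `CC(C)=CCC/C=C(\C)Cc1c(OC/C=C(\C)CCC=C(C)C)c(C/C=C(\C)CCC=C(C)C)c(O)c2c(=O)cc(-c3ccccc3)oc12` keeps all of compound 3 and adds one change: 3,7-dimethylocta-2,6-dien-1-yl in place of hydrogen on an aromatic carbon. Within the data shown here, the one measured step bearing on this is an at least 3.1-fold higher number from compound 1 to compound 3 (0.49 log units; beyond the scatter), where the same group entered on an oxygen instead. In this assay a shift to a lower number is not expected, and any readable shift should be towards a higher one. The expected step is a number no higher from compound 3 to compound 4 (the limit leaves the size open). The estimate for compound 4 is 100000 nM, with an expected range of 40000 nM to 200000 nM.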

Compound 4, half-maximal inhibitory concentration: 32000 nM
For compound 4 the middle estimate is 3.1-fold (0.49 log units) above the measured one, and the stated range ends above it.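

In this assay, the aromatic carbon ortho to the (3,7-dimethylocta-2,6-dien-1-yl)oxy group and ortho to the hydroxy group takes a further 3,7-dimethylocta-2,6-dien-1-yl chain, with an at least 3.1-fold lower number from compound 3 to compound 4 (0.49 log units; beyond the scatter). The same group on oxygen went the other way, with an at least 3.1-fold higher number from compound 1 to compound 3 (0.49 log units; beyond the scatter), so across these two steps the direction follows the place of attachment, not the group alone. The size of the new step stays open, since compound 3 carries only a limit: the limit of > 100000 nM in this assay, at which 2 of the 4 values shown sit.

Left open is whether the chain on this aromatic carbon acts the same when the neighbouring oxygen keeps its hydrogen. Also open, as far as these compounds go, is whether a shorter chain, such as 3-methylbut-2-en-1-yl, or an amine at this carbon gives a lower number still.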